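The source may hold more compounds than are shown below. What is called first, only, known or untested is meant among the compounds shown, and "the series" means these compounds.

Compound 1 `CS(=O)(=O)Nc1ccc(-n2cc(-c3ccccc3)nn2)cc1Oc1ccccc1`: 13600 nM
Compound 2 `Cc1ccc(OCc2cn(-c3ccc(NS(C)(=O)=O)c(Oc4ccccc4)c3)nn2)cc1`: 13000 nM
Compound 3 `Cc1cc(OCc2cn(-c3ccc(NS(C)(=O)=O)c(Oc4ccccc4)c3)nn2)ccc1Cl`: 9800 nM

These values come from a functional assay on HepG2 cells (Homo sapiens) for inhibition, read by MTT assay, with a stated time of 48 h; a higher number here means a weaker inhibitor, a lower number a stronger inhibitor. Compound 3, at 9800 nM, lies within the scatter of both other compounds. Compound 4 `CS(=O)(=O)Nc1ccc(-n2cc(COc3ccc(Cl)cc3)nn2)cc1Oc1ccccc1` differs from compound 3 as follows: hydrogen in place of methyl on an aromatic carbon. This is hydrogen in place of methyl on an aromatic carbon, so 4-chloro-3-methylphenyl becomes 4-chlorophenyl. The closest measured evidence is a 1.3-fold lower number from compound 2 to compound 3 (0.12 log units; within the scatter), where 4-chloro-3-methylphenyl replaced 4-methylphenyl. The larger exchanges, a 1.0-fold lower number from compound 1 to compound 2 (0.02 log units; within the scatter) and a 1.4-fold lower number from compound 1 to compound 3 (0.14 log units; within the scatter), also stayed within the scatter. No step beyond the scatter is therefore expected in this assay. The estimated change is a 1.1-fold higher number from compound 3 to compound 4 (0.05 log units; within the scatter). Compound 4 is expected at 11000 nM, with an estimated range of 6000 nM to 20000 nM.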

Compound 4, half-maximal inhibitory concentration: 7500 nM
The estimate for compound 4 lay 1.5-fold (0.17 log units) above the measured number; low and high end bracket the measured number.
By their numbers in this assay, from the lowest: compounds 4, 3, 2 and 1 (each within the scatter of the next).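

In this assay, hydrogen in place of methyl on this aromatic carbon, ortho to the chloro group, stays within the scatter (a 1.3-fold lower number from compound 3 to compound 4 (0.12 log units; within the scatter)), so compound 3 and compound 4 cannot be told apart. Chloro in place of methyl (a 1.7-fold lower number from compound 2 to compound 4 (0.24 log units; within the scatter)) and (4-chlorophenoxy)methyl in place of phenyl (a 1.8-fold lower number from compound 1 to compound 4 (0.26 log units; within the scatter)) also stay within it, leaving all four compounds within the scatter of one another. No measurement offers an explanation for these steps.

Going by these compounds, whether methoxy, an amine or a carboxylic acid in place of the chloro group would carry the number beyond the scatter remains open.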